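Amide replacement on the shared core at melanocortin receptor 4

The compounds below may be only part of what the source reports. "The series", "measured", "known", "first", "only" and "open" are said of these compounds alone.

Compound 1 `CC(C)N(C(=O)CN1C=CN(c2ccccc2)C(=O)C(Cc2n[nH]c3ccccc23)C1=O)c1ccc(O)cc1` is the reference with repeated entries. In a functional assay on CHO cells for agonist activity at Melanocortin receptor 4 (Homo sapiens), read by a luciferase reporter, with a stated time of 4 h (on this read-out lower numbers stand for an effect already at smaller amounts and higher numbers for an effect only at larger amounts of compound), compound 1 gives 1000 nM; 1000 nM; 31600 nM; > 30000 nM (4 entries). Compound 2 `COc1ccc(N(C(=O)CN2C=CN(c3ccccc3)C(=O)[C@H](Cc3n[nH]c4ccccc34)C2=O)C(C)C)cc1` stands as the only single number shown for it, with one further entry that has no number; in this assay compound 2 gives 339 nM. The spread of compound 1 in the several entries of compound 1 in this assay, 1000 nM; 1000 nM; 31600 nM; > 30000 nM (4 entries) marks how widely repeats of this kind can fall.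

Compound 3 `O=C1[C@@H](Cc2n[nH]c3ccccc23)C(=O)N(c2ccccc2)C=CN1CC(=O)N1CCCCc2ccccc21` is not yet measured. It differs from compound 2 in a group of 11 heavy atoms (10 carbon, 1 nitrogen; one six-membered aromatic ring of carbon only, one seven-membered non-aromatic ring with 1 hetero atom) in place of a group of 12 heavy atoms (10 carbon, 1 nitrogen, 1 oxygen; one six-membered aromatic ring of carbon only), on a carbonyl carbon. Within the data shown here, no measured pair covers this change. The step from compound 2 to compound 3 is expected as a 3.5-fold higher number from compound 2 to compound 3 (0.55 log units; beyond the scatter), a loss of potency beyond the scatter. Compound 3 is estimated at 1200 nM in this assay, with a range from 250 nM to 8000 nM.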

Compound 3, half-maximal effective concentration: 100 nM
Compound 3: the middle estimate sits 12-fold (1.08 log units) above what was measured, and the stated range ends above it.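

In this assay, the carbonyl carbon accepts a group with a seven-membered non-aromatic ring in place of isopropyl(4-methoxyphenyl)amino, with a 3.4-fold lower number from compound 2 to compound 3 (0.53 log units; beyond the scatter). So the isopropyl and the methoxy oxygen are not needed for agonist activity at this position, and the entering group, with 0 hydrogen-bond acceptors, still gives a lower number than the group it replaces. The step is printed as beyond the scatter, but it rests on one value for compound 3, and the repeats on the shared core fall widely: the several entries of compound 1 in this assay, 1000 nM; 1000 nM; 31600 nM; > 30000 nM (4 entries)

Among these compounds, the single step changes the whole group at once, so the shares of the ring and of the lost methoxy in this difference cannot be separated. Also open, on these data alone, is how a six-membered non-aromatic ring in the same place, or an amine or carboxylic acid on the aromatic ring of the entering group, would read in this assay.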